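From a Sulfanyl to a Sulfonyl Side Group

The source may report more compounds than this note shows. Statements on the series, on what has been measured and on what is new or still open speak of the compounds shown alone.

Of the compounds shown here, two that share a core have been tested so far in a functional assay on DU-145 cells (Homo sapiens) for inhibition, read by trypan blue exclusion, with a stated time of 96 h; on this read-out higher numbers stand for weaker inhibition of growth and lower numbers for stronger inhibition of growth. In this test, compound 1 `COc1cc(OC)c(/C=C(/C(=O)c2ccc(Cl)cc2)[S+]([O-])Cc2ccccc2Cl)c(OC)c1` gives 10000 nM. Compound 2 `COc1cc(OC)c(/C=C(/SCc2ccc(Cl)c(Cl)c2)C(=O)c2ccc(Cl)cc2)c(OC)c1` gives 10000 nM, which places compound 2 level with compound 1, within the usual scatter of repeated measurements.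

Compound 3 `COc1cc(OC)c(/C=C(\C(=O)c2ccc(Cl)cc2)S(=O)(=O)Cc2ccc(F)cc2)c(OC)c1` has not yet been measured. It has (4-fluorobenzyl)sulfonyl in place of (3,4-dichlorobenzyl)sulfanyl on a double-bonded chain carbon bound to a carbonyl carbon and a double-bonded chain carbon.

Within the data shown here, no measured pair shows what this exact change does, so the expectation is a cautious judgement rather than a calculation. The expected change is a 6.7-fold lower number from compound 2 to compound 3 (0.82 log units; beyond the scatter), a move beyond the scatter towards stronger inhibition of growth, although no change at all would not be surprising. For compound 3, the estimated value is 1500 nM, with an expected range from 100 nM to 15000 nM.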

Compound 3, concentration for 50% growth inhibition: 25000 nM
The estimate for compound 3 lay 17-fold (1.22 log units) below the measured number, outside the stated range (above it).
By their numbers in this assay, from the lowest: compounds 1 and 2 (each within the scatter of the next); then compound 3.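

Until now no single change could be followed at this position, and the first one that can be read goes the wrong way for potency: in this assay, the swap gives a 2.5-fold higher number from compound 2 to compound 3 (0.40 log units; beyond the scatter), a modest move towards weaker inhibition of growth. So replacing (3,4-dichlorobenzyl)sulfanyl with (4-fluorobenzyl)sulfonyl on this double-bonded chain carbon does not strengthen inhibition here, although the group is only slightly larger by heavy atom count and adds one hydrogen-bond acceptor. Nothing measured here explains the loss, and no supporting data bear on its cause.

This single swap alters both the sulfur-containing link and the halogens on the benzyl ring, so the compounds shown cannot say which alteration accounts for the step, a question that (3,4-dichlorobenzyl)sulfonyl or (4-fluorobenzyl)sulfanyl at the same place could help to separate. On these data alone, it also stays open how this position would respond to a quite different side group, such as a chain ending in an amine or a carboxylic acid.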